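The source may hold more compounds than are shown below. What is called first, only, known or untested is meant among the compounds shown, and "the series" means these compounds.

Measured compounds:
Compound 1, `CCC(C)(C)Cc1c[nH]c(CCc2ccc(-c3csnn3)cc2)n1`, gives 45 nM in an in vitro assay on CHO cells for displacement of a labelled ligand from Bombesin receptor subtype-3 (Homo sapiens), read by scintillation counting, with a stated time of 2 h; a higher number here means a weaker inhibitor, a lower number a stronger inhibitor.
Compound 2, `CCC(C)(C)Cc1c[nH]c(CCc2ccc(-c3cnccn3)cc2)n1`, gives 51 nM in this assay.

Among the compounds with values here, of the two numbers so far, compound 2 nominally holds the higher one, but its only neighbour is compound 1, and the step of a 1.1-fold higher number from compound 1 to compound 2 (0.05 log units; within the scatter) lies within the scatter, so the two compounds cannot be ordered in this assay. Compound 3, `CCC(C)(C)Cc1c[nH]c(CCc2ccc(-c3cnsc3)cc2)n1`, has not yet been measured. It differs from compound 2 in one place: 1,2-thiazol-4-yl in place of pyrazin-2-yl on an aromatic carbon. Within the data shown here, only one measured step bears on this change, and only loosely: it exchanged one aromatic ring for another on the same aromatic carbon and moved the number by a 1.1-fold higher number from compound 1 to compound 2 (0.05 log units; within the scatter), within the scatter. On that basis compound 3 is expected to sit close to compound 2, with no step beyond the scatter, and the expected step is a 1.1-fold lower number from compound 2 to compound 3 (0.05 log units; within the scatter). Compound 3 is therefore estimated at 45 nM in this assay, within a range from 20 nM to 110 nM.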

Compound 3, half-maximal inhibitory concentration: 10 nM
Beside the measured number, compound 3's estimate is 4.5-fold (0.65 log units) above it; the whole stated range lies above it.
By their numbers in this assay, from the lowest: compound 3; then compounds 1 and 2 (each within the scatter of the next).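

Within the data shown here, the ring on this aromatic carbon, para to a large group, proves able to move the number in this assay: with 1,2-thiazol-4-yl in place of pyrazin-2-yl, the result is a 5.1-fold lower number from compound 2 to compound 3 (0.71 log units; beyond the scatter), whereas the only earlier exchange of one ring for another stayed within the scatter. Ring size alone does not describe the change, since compound 1 also carries a five-membered ring, 1,2,3-thiadiazol-4-yl, and the replacement of that ring by 1,2-thiazol-4-yl gives a 4.5-fold lower number from compound 1 to compound 3 (0.65 log units; beyond the scatter), so the two rings of the same size are clearly separated; compound 3 is thus the strongest inhibitor of the three, with both of its steps beyond the scatter. No measurement available here accounts for the difference between these rings.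

From the compounds shown here alone, it remains open how a plain phenyl ring or a 1,3-thiazol-5-yl ring would compare at this place, and whether a methyl group or an amine could be carried on the 1,2-thiazol-4-yl ring without losing the advantage. Also open, going by these compounds, is whether that advantage would persist with a shorter chain in place of the branched chain on the shared core.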